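The source may report more compounds than this note shows. Statements on the series, on what has been measured and on what is new or still open speak of the compounds shown alone.

Compound 1 `CCCNc1nc(NCc2ccc(C(=O)NCc3ccc(F)cc3)cc2)c2cc(C)ccc2n1` is the weaker of the two measured compounds: in a functional assay on HCT-116 cells (Homo sapiens) for inhibition, read by luminescence and resazurin assay, with a stated time of 3 days (a higher number here means a weaker inhibitor, a lower number a stronger inhibitor), compound 1 gives 4400 nM. Going by the values given here, its only measured neighbour is compound 2 `CCCNc1nc(NCc2ccc(C(=O)Nc3ccc(Cl)nc3)cc2)c2cc(C)ccc2n1`, which in this assay gives 1500 nM; that pair shows a 2.9-fold lower number from compound 1 to compound 2 (0.47 log units; beyond the scatter), a change made at the amide end of the molecule. Compound 3 `Cc1ccc2nc(N3CCNC(C)C3)nc(NCc3ccc(C(=O)NCc4ccc(F)cc4)cc3)c2c1` differs from compound 1 elsewhere, on the shared core: 3-methylpiperazin-1-yl in place of propylamino on an aromatic carbon. Among the compounds with values here, no measured step touches this position, so the one known step gives no guide to what this change does, and there is no basis for expecting a shift in either direction beyond the scatter. On that footing the number for compound 3 in this assay is expected to be 4000 nM, somewhere between 1000 nM and 16000 nM, which would mean a step of a 1.1-fold lower number from compound 1 to compound 3 (0.04 log units; within the scatter) from compound 1; the measured result will tell.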

Compound 3, half-maximal inhibitory concentration: 2900 nM
Estimate against measurement, compound 3: 1.4-fold (0.14 log units) above, within the range that was stated.
By their numbers in this assay, from the lowest: compounds 2, 3 and 1 (each within the scatter of the next, the first and the last beyond it).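

In this assay, putting 3-methylpiperazin-1-yl in place of propylamino on the aromatic carbon between two ring nitrogen atoms gives a 1.5-fold lower number from compound 1 to compound 3 (0.18 log units; within the scatter). Going by these compounds alone, this is the first look at this position, and it shows that an open chain can give way to a larger six-membered ring carrying a second nitrogen without a shift beyond the scatter. Nothing shown explains why the number stays this close.

The compounds shown do not separate the roles of the ring, its second nitrogen and its methyl group, which a plain piperazin-1-yl, a morpholin-4-yl or a longer chain such as butylamino could help to tease apart. Also open, as far as these compounds go, is whether 3-methylpiperazin-1-yl would behave the same way with the 6-chloropyridin-3-yl group of compound 2 at the amide end.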